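This account rests on a few compounds, and the source may have more. Where it says the series, first, only, none or still open, it means among the compounds named here.

Within the data shown here, the three compounds measured so far share one core, seen in compound 1 `O=C1/C(=C\c2ccc(O)cc2)c2ccccc2N1c1c(Cl)cccc1Cl`, compound 2 `O=C1/C(=C\c2cccc(Oc3ccccc3)c2)c2ccccc2N1c1c(Cl)cccc1Cl` and compound 3 `COc1ccc(/C=C2\C(=O)N(c3c(Cl)cccc3Cl)c3ccccc32)cc1`, and differ only in the aromatic ring attached to the double-bonded chain carbon. In a functional assay on MIA PaCa-2 cells (Homo sapiens) for cytotoxicity, read by MTT assay, with a stated time of 72 h (on this read-out higher numbers stand for an effect only at larger amounts of compound and lower numbers for an effect already at smaller amounts), compound 1 gives 2 ug/mL. For compound 2 this assay reports only a limit, > 100 ug/mL. Compound 3 likewise reaches only a limit, > 100 ug/mL. So compound 3 stands at the top edge of what this assay can report, with compound 1 the only one that yields a number. Among the measured compounds shown here, the single step connecting measured compounds, an at least 50-fold higher number from compound 1 to compound 3 (1.69 log units; beyond the scatter), is large, and the limit of > 100 ug/mL in this assay, at which 2 of the 3 values shown sit, means its true size is unknown. Compound 4 `O=C1/C(=C\c2cccc(Br)c2)c2ccccc2N1c1c(Cl)cccc1Cl` differs from compound 3 by 3-bromophenyl in place of 4-methoxyphenyl on a double-bonded chain carbon bound to a double-bonded ring carbon. For the measured compounds named here, no measured pair shows this exact change, but the one numbered result belongs to compound 1, whose ring carries a free hydroxyl, and both rings lacking it sit at the limit. Compound 4 is therefore expected to be weak, around 50 ug/mL with a range from 10 ug/mL to 200 ug/mL, which would mean an estimated at least 2.0-fold lower number from compound 3 to compound 4 (0.30 log units; that floor lies within the scatter), with a fair chance that only a limit is reported again.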

Compound 4, concentration for half-maximal effect: 5 ug/mL
Beside the measured number, compound 4's estimate is 10-fold (1.00 log units) above it, and the stated range ends above it.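

In this assay, a free hydroxyl turns out not to be required for a measurable effect at this position, since 3-bromophenyl on the double-bonded chain carbon also gives a number, with an at least 20-fold lower number from compound 3 to compound 4 (1.30 log units; beyond the scatter) and an at least 20-fold lower number from compound 2 to compound 4 (1.30 log units; beyond the scatter). The hydroxyl compound still keeps a small edge, with a 2.5-fold higher number from compound 1 to compound 4 (0.40 log units; beyond the scatter), a modest step. Going by these compounds, how large the other two steps really are stays unknown because one end of each is a limit: the limit of > 100 ug/mL in this assay, at which 2 of the 4 values shown sit.

The change from 4-methoxyphenyl to 3-bromophenyl alters both the group and where it sits, so the compounds shown cannot separate these two effects, and 4-bromophenyl or 3-hydroxyphenyl would be needed to do so. On these data alone, whether an amine or a carboxylic acid on this ring would also give a number remains open.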